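The source may hold more compounds than are shown below. What is called first, only, known or untested is meant among the compounds shown, and "the series" means these compounds.

Of the compounds shown here, two have so far been measured in a functional assay on HT-29 cells (Homo sapiens) for antiproliferative activity, read by MTT assay, with a stated time of 72 h; on this read-out lower numbers stand for stronger inhibition and higher numbers for weaker inhibition. Compound 1, `COc1cc2c(Oc3ccc(NC(=O)NN4C(=O)CSC4c4c(F)cccc4F)c(Cl)c3)ccnc2cc1OCCCN1CCCC1`, gives 630 nM there, and compound 2, `COc1cc2c(Oc3c(F)cc(NC(=O)NN4C(=O)CCSC4c4c(F)cccc4F)cc3F)ccnc2cc1OCCCN1CCc2sccc2C1`, gives 1320 nM. Compound 2 therefore shows the higher of the two numbers, and its gap to compound 1 lies beyond the usual scatter; the two structures differ in several places at once, so no single step can be read from that pair. Compound 3, `COc1cc2c(Oc3c(F)cc(NC(=O)NN4C(=O)CCSC4c4c(F)cccc4F)cc3F)ccnc2cc1OCCCN1C[C@H]2CCCC[C@H]2C1`, differs from compound 2 in one place only: a group of 9 heavy atoms (8 carbon, 1 nitrogen; one five-membered non-aromatic ring with 1 hetero atom, one six-membered non-aromatic ring of carbon only) in place of a group of 9 heavy atoms (7 carbon, 1 nitrogen, 1 sulfur; one five-membered aromatic ring with 1 hetero atom, one six-membered non-aromatic ring with 1 hetero atom), on a saturated chain carbon, three bonds along the chain from an oxygen on an aromatic ring. Going by the values given here, no measured pair in this assay shows a change of this kind, so the size of the step rests on an expectation rather than on a precedent, and the expectation is a small step with no clear direction beyond the scatter. On that basis compound 3 is estimated at 1000 nM, within a range from 400 nM to 2500 nM. That estimate means an expected step of a 1.3-fold lower number from compound 2 to compound 3 (0.12 log units; within the scatter), staying within the scatter.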

Compound 3, half-maximal inhibitory concentration: 790 nM
Beside the measured number, compound 3's estimate is 1.3-fold (0.10 log units) above it; the range from low to high includes it.
By their numbers in this assay, from the lowest: compounds 1, 3 and 2 (each within the scatter of the next, the first and the last beyond it).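

In this assay, going by these compounds alone, the earlier compounds gave no step in one place, and this pair gives the first at a saturated chain carbon, three bonds along the chain from an oxygen on an aromatic ring (a 1.7-fold lower number from compound 2 to compound 3 (0.22 log units; within the scatter)). The group that enters has a five-membered non-aromatic ring and a six-membered carbon-only ring, and it carries 2 defined stereocentres; the group that leaves has a five-membered aromatic ring and a sulfur, so in this one pair, removing that aromatic ring and sulfur moves the number no further than the scatter. No measurement at hand explains this result.

On these data alone, whether a morpholine or a simple dimethylamine at the same place would read alike remains open. So does the effect of the other arrangements of the 2 defined stereocentres in compound 3.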